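Amide variation in a dimethoxy-substituted writhing-test series

This account rests on a few compounds, and the source may have more. Where it says the series, first, only, none or still open, it means among the compounds named here.

Compound 1 `COc1cc2c(cc1OC)C(CC(N)=O)CC2`: 24.6%
Compound 2 `CCN(CC)C(=O)CC1CCc2cc(OC)c(OC)cc21`: 27.4%
Compound 3 `CCCNC(=O)CC1CCc2cc(OC)c(OC)cc21`: 26.9%

The three measured compounds share one core and differ only in the amide group. In a functional assay on the whole organism (strain Swiss albino) for inhibition, with Mus musculus as the target, in the writhing test, with stated times of 60 min and 15 min, at a dose of 100 mg/kg by the oral route (a higher number here means more inhibition at the dose given (going by the name of the read-out), a lower number less inhibition), compound 1 gives 24.6%, compound 2 gives 27.4% and compound 3 gives 26.9%. Compound 3 stands second of the three numbers, but no two of them are separated by more than the scatter: a number 2.8 percentage points higher from compound 1 to compound 2 (within the scatter), a number 2.3 percentage points higher from compound 1 to compound 3 (within the scatter) and a number 0.5 percentage points lower from compound 2 to compound 3 (within the scatter).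

Compound 4 `COc1cc2c(cc1OC)C(CC(=O)N1CCCC1)CC2` is the next member. Its change from compound 3 is pyrrolidin-1-yl in place of propylamino on a carbonyl carbon.

For the measured compounds named here, the steps that bear on this change are those that alter the amide nitrogen: from amino to diethylamino, from hydrogen to propyl on the amide nitrogen, and from diethylamino to propylamino. Each of them stayed within the scatter, so the series gives no indication that the amide substituent moves the number in this assay. Going by the values given here, the move to a ring-closed amine is a new kind of change, but there is no measured step that suggests a departure from the pattern. Compound 4 is therefore expected to show no step beyond the scatter, a number 0.1 percentage points higher from compound 3 to compound 4 (within the scatter), and its estimated value in this assay is 27%, expected to lie between 17% and 37%.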

Compound 4, a percentage reported as inhibition, in the whole organism at one dose (the size of the read-out at that dose, not a potency): 19.2%
Estimate against measurement, compound 4: 7.8 percentage points above, and the stated range covers the measured number.
By their numbers in this assay, from the lowest: compounds 4, 1, 3 and 2 (each within the scatter of the next).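

In this assay, the change to pyrrolidin-1-yl on the carbonyl carbon gives the widest steps in the set, a number 7.7 percentage points lower from compound 3 to compound 4 (within the scatter), a number 8.2 percentage points lower from compound 2 to compound 4 (within the scatter) and a number 5.4 percentage points lower from compound 1 to compound 4 (within the scatter). For the compounds shown here, this place has now carried amino, diethylamino, propylamino and a group with a five-membered non-aromatic ring, and no step among the four compounds lies beyond the scatter, so the ring cannot be said to set compound 4 apart from the open-chain amides. Nothing available explains these numbers or shows whether the widest steps reflect anything more than the scatter.

From the compounds shown here alone, it remains open whether another ring on the amide nitrogen, such as piperidine or morpholine, or a longer chain, such as hexyl, would give a step beyond the scatter. Because the core stays the same throughout and each compound is read at a single dose, the four compounds also leave open what replacing the methoxy groups would do and how potency would compare across the amides.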